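A Second Chloro on a Compound at the Limit

This account rests on a few compounds, and the source may have more. Where it says the series, first, only, none or still open, it means among the compounds named here.

In a functional assay on HepG2 cells (Homo sapiens) for cytotoxicity, with a stated time of 72 h (a lower number here means that less compound is needed, a higher number that more compound is needed for the effect), compound 1 (`C=C[C@@](C)(/C=C/c1ccc(OCc2ccccc2)cc1)CCC=C(C)C`) gives > 52000 nM, which is a limit and not a number. Compound 2 (`C=C[C@@](C)(/C=C/c1ccc(-c2ccc(Cl)cc2)cc1)CCC=C(C)C`) gives > 52000 nM, which is also a limit. So compound 2 has no exact value, and the data show only (the limit of > 52000 nM in this assay, at which 2 of the 2 values shown sit).

Among the compounds with values here, the one measured step that bears on what follows is a step that the two limits leave unreadable from compound 1 to compound 2, with 4-chlorophenyl in place of benzyloxy on an aromatic carbon. It gives no size to carry forward and no direction.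

Compound 3 (`C=C[C@@](C)(/C=C/c1ccc(-c2ccc(Cl)c(Cl)c2)cc1)CCC=C(C)C`) adds one further change: chloro in place of hydrogen on an aromatic carbon, taking 4-chlorophenyl to 3,4-dichlorophenyl (chloro in place of hydrogen on an aromatic carbon). The new chloro stands ortho to a chloro group and meta to a large group.

With no readable step as a guide, no clear move in this assay is expected, and another limit is the likeliest report. The expected change is a step that the limit leaves unreadable from compound 2 to compound 3, a rough estimate with no firm direction. For compound 3 the estimated value is 55000 nM, with an expected range from 25000 nM to 100000 nM.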

Compound 3, half-maximal effective concentration: > 52000 nM
Compound 3: a limit, no number (the forecaster's own chance of this, stated with the estimate: 80%); the middle value is on the limit's open side.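

In this assay compound 3 gives > 52000 nM, which is a limit and not a number. The steps among compound 1, compound 2 and compound 3 therefore cannot be read, in size or in direction: the limit of > 52000 nM in this assay, at which 3 of the 3 values shown sit. The compounds shown leave open whether the added chloro, or replacing benzyloxy, changes the concentration needed for the effect at all.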